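Indole-oxadiazoles: a trifluoromethyl variant at the detection limit

The compounds below may be only part of what the source reports. "The series", "measured", "known", "first", "only" and "open" are said of these compounds alone.

Compound 1 `c1ccc(Cc2nnc(-c3c[nH]c4ccccc34)o2)cc1`: > 1000000 nM
Compound 2 `COc1ccc(-c2nnc(-c3c[nH]c4ccccc34)o2)cc1`: > 1000000 nM
Compound 3 `COc1cc(-c2nnc(-c3cn(C)c4ccccc34)o2)ccc1OCc1ccccc1`: > 1000000 nM

The three measured compounds share a core in which an indole-type ring carries a five-membered aromatic ring with two nitrogens and one oxygen. In a functional assay on LNCaP cells (Homo sapiens) for cytotoxicity, read by MTT assay (on this read-out higher numbers stand for weaker inhibition and lower numbers for stronger inhibition), compound 1 gives > 1000000 nM, which is a limit of the assay and not a number. Compound 2 likewise gives only a limit, > 1000000 nM. Compound 3 also gives only a limit, > 1000000 nM. So compound 1 stands at the same limit as every other value shown, as summarised by the limit of > 1000000 nM in this assay, at which 3 of the 3 values shown sit; no ordering among the three can be read from these data, and no measured step exists between any two of them.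

Compound 4 `FC(F)(F)c1nnc(-c2c[nH]c3ccccc23)o1` differs from compound 1 by trifluoromethyl in place of benzyl on an aromatic carbon. Among the compounds with values here, since all three measured values sit at the limit, there is no measured step on which to base a direction. The step from compound 1 to compound 4 is therefore expected to be none beyond the scatter, and the expectation is that compound 4 will again be reported as a limit rather than a number; the expected step is a number no higher from compound 1 to compound 4 (the limit leaves the size open). For compound 4 the estimate in this assay is 1000000 nM, within a range from 300000 nM to 3000000 nM.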

Compound 4, half-maximal inhibitory concentration: > 1000000 nM
Compound 4 was reported as a limit (the forecaster's own chance of this, stated with the estimate: 85%); the middle value sits exactly at the limit.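

No step from compound 1 to compound 4 can be read in this assay, because each of the two compounds is reported only as a limit of the assay and not as a number: the limit of > 1000000 nM in this assay, at which 4 of the 4 values shown sit.

The compounds shown leave open how trifluoromethyl and benzyl compare, and whether any compound with the shared core reaches a measurable value in this assay.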